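The source may hold more compounds than are shown below. What is called first, only, known or untested is meant among the compounds shown, and "the series" means these compounds.

In an ADME assay on HEK293 cells (Homo sapiens) for cytotoxicity, read by resazurin assay, with a stated time of 72 h (a higher number here means that more compound is tolerated, a lower number that less compound is tolerated), compound 1 `O=C(O)c1ccc(CCOc2c(F)ccc3nc(C(=O)NCc4ccccc4)[nH]c(=O)c23)cc1` gives > 20000 nM, a limit and not a number. Compound 2 `CCc1cccc(NC(=O)c2nc3ccc(F)c(OCCc4ccc(C(=O)O)cc4)c3c(=O)[nH]2)c1` gives > 20000 nM, also a limit. Among the compounds with values here, the only measured step, a step that the two limits leave unreadable from compound 1 to compound 2, has no readable size, and the limit of > 20000 nM in this assay, at which 2 of the 2 values shown sit, is the only evidence bearing on this change. Compound 3 `CCc1cccc(C(C)NC(=O)c2nc3ccc(F)c(OCCc4ccc(C(=O)O)cc4)c3c(=O)[nH]2)c1` differs from compound 2 by 1-(3-ethylphenyl)ethyl in place of 3-ethylphenyl on an amide-type nitrogen. No step beyond the scatter is expected, and the estimate is a step that the limit leaves unreadable from compound 2 to compound 3. Compound 3 is expected at 25000 nM, with an estimated range of 12000 nM to 50000 nM, and a further limit is likely.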

Compound 3, half-maximal cytotoxic concentration: > 20000 nM
Compound 3: a limit, no number; the forecaster's own chance of this, stated with the estimate: 85%; the middle value does not contradict the limit.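

No step among compound 1, compound 2 and compound 3 can be read, since all three rest on the same limit: the limit of > 20000 nM in this assay, at which 3 of the 3 values shown sit.

Going by these compounds, still open in this assay is what the changes on the amide-type nitrogen do to the half-maximal cytotoxic concentration, which none of the three compounds gives as a number.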